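The compounds below may be only part of what the source reports. "The series", "measured", "known", "first", "only" and "open" are said of these compounds alone.

Of the compounds shown here, three that share one core have been tested in a functional assay on HeLa cells (Homo sapiens) for cytotoxicity, read by MTT assay; on this read-out lower numbers stand for stronger inhibition and higher numbers for weaker inhibition. Compound 1 `CC(C)=CC[C@@H](OC(=O)c1ccoc1)C1=CC(=O)c2c(O)ccc(O)c2C1=O` gave only a limit of the assay, > 100000 nM. Compound 2 `CC(C)=CC[C@@H](OC[C@@H](C)O)C1=CC(=O)c2c(O)ccc(O)c2C1=O` gave 22500 nM, while compound 3 `CC(C)=CC[C@@H](OC(=O)CC(C)(O)c1ccccc1)C1=CC(=O)c2c(O)ccc(O)c2C1=O` gave 85700 nM. Of the two real numbers, compound 2 has the lower one, and compound 3 sits a clear step above it. The step of an at least 4.4-fold lower number from compound 1 to compound 2 (0.64 log units; beyond the scatter) shows that swapping the ester for an alcohol-bearing ether lowered the number, whereas the step of an at least 1.1-fold lower number from compound 1 to compound 3 (0.06 log units; that floor lies within the scatter), which kept an ester and brought in a hydroxy-bearing chain, did not move it beyond the scatter; here compound 1 sits at the limit of > 100000 nM in this assay, at which 1 of the 3 values shown sits.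

Compound 4 `CCCC(C)(O)CC(=O)O[C@H](CC=C(C)C)C1=CC(=O)c2c(O)ccc(O)c2C1=O` returns from the ether to an ester: (2-hydroxy-2-methylpentyl)carbonyl in place of 2-hydroxypropyl on an oxygen on a saturated carbon. The entering group resembles the ester of compound 3, whose value of 85700 nM lies well above that of compound 2. Going back to an ester is therefore expected to raise the number, and the expected step in this assay is a 2.7-fold higher number from compound 2 to compound 4 (0.43 log units; beyond the scatter). Compound 4 is thus estimated at 60000 nM, with a likely range from 20000 nM to 150000 nM, and a fair chance that only a limit is reported.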

Compound 4, half-maximal inhibitory concentration: 72000 nM
Beside the measured number, compound 4's estimate is 1.2-fold (0.08 log units) below it; measured number inside the range.
By their numbers in this assay, from the lowest: compound 2; then compounds 4 and 3 (each within the scatter of the next). At a limit, above all of these: compound 1.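

On this oxygen, (2-hydroxy-2-methylpentyl)carbonyl in place of 2-hydroxypropyl gives a 3.2-fold higher number from compound 2 to compound 4 (0.51 log units; beyond the scatter) in this assay, so a second ester now stands clearly above the ether compound, and this ester carries no ring. Propyl in place of phenyl on the hydroxy-bearing chain carbon gives a 1.2-fold lower number from compound 3 to compound 4 (0.08 log units; within the scatter) and so does not separate these two esters, which means the phenyl group of the earlier ester makes no readable difference in this pair. The comparison with the furan-3-yl ester gives an at least 1.3-fold lower number from compound 1 to compound 4 (0.14 log units; that floor lies within the scatter) and provides only a floor, with compound 1 at a limit of the assay: the limit of > 100000 nM in this assay, at which 1 of the 4 values shown sits.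

Going by these compounds, compound 4 changes both the link to the core and the length of the chain at once, so it remains open which of the two goes with the lower number of compound 2. An ether carrying the longer 2-hydroxy-2-methylpentyl chain, or an amine in place of the oxygen, would help to pull these two changes apart.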